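The source may hold more compounds than are shown below. What is called first, only, known or untested is meant among the compounds shown, and "the series" means these compounds.

Measured compounds:
Compound 1 `Cc1ccc(CN2CCC(c3noc(COc4ccc(/C=C/C(=O)NO)cc4)n3)CC2)cc1` gives 76% in an assay on isolated protein for inhibition of protein deacetylase HDAC6 (Homo sapiens), read by fluorescence, with a stated time of 1 h, tested at 100 nM; on this read-out lower numbers stand for less inhibition and higher numbers for more inhibition at the one concentration tested (going by the name of the read-out).
Compound 2 `O=C(/C=C/c1ccc(OCc2nc(C3CCN(Cc4ccccc4Cl)CC3)no2)cc1)NO` gives 59% in this assay.
Compound 3 `N#Cc1ccc(CN2CCC(c3noc(COc4ccc(/C=C/C(=O)NO)cc4)n3)CC2)cc1` gives 65% in this assay.

Compound 1 stands highest of the three; the nearest is compound 3, a step of a number 11 percentage points lower from compound 1 to compound 3 (beyond the scatter), and the furthest is compound 2, a step of a number 17 percentage points lower from compound 1 to compound 2 (beyond the scatter). Between compound 2 and compound 3 the step is a number 6 percentage points higher from compound 2 to compound 3 (within the scatter), which is within the scatter.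

The unmeasured compound 4 `Cc1ccc(CN2CCC(c3noc(COc4ccc(CCC(=O)NO)cc4)n3)CC2)cc1` differs from compound 1 in one place:
2-(hydroxycarbamoyl)ethyl in place of 2-(hydroxycarbamoyl)ethenyl on an aromatic carbon
Every measured step changes the group on the saturated chain carbon bound to the amine nitrogen in the ring, at the other end of the shared core. For the measured compounds named here, none of them touches the 2-(hydroxycarbamoyl)ethenyl group, so there is no measured step that bears directly on this change, and the expectation rests on compound 1 alone. Since the change removes one double bond outside aromatic rings from the side of the molecule that carries the hydroxycarbamoyl group, a drop beyond the scatter is expected in this assay, estimated as a number 26 percentage points lower from compound 1 to compound 4 (beyond the scatter). Compound 4 is therefore expected to give about 50%, within a range from 25% to 72%.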

Compound 4, a percentage reported as inhibition, at one concentration (the size of the read-out at that concentration, not a potency): 28%
Compound 4: the middle estimate sits 22 percentage points above what was measured; low and high end bracket the measured number.
By their numbers in this assay, from the lowest: compound 4; then compounds 2 and 3 (each within the scatter of the next); then compound 1.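

The first change shown at this end of the molecule, 2-(hydroxycarbamoyl)ethyl in place of 2-(hydroxycarbamoyl)ethenyl on an aromatic carbon, gives in this assay a step of a number 48 percentage points lower from compound 1 to compound 4 (beyond the scatter) and counts as large. The two groups match in heavy atoms and in hydrogen-bond donors and acceptors and differ by one double bond outside aromatic rings, so this single difference goes with a larger step than either change at the other end, a number 17 percentage points lower from compound 1 to compound 2 (beyond the scatter) and a number 11 percentage points lower from compound 1 to compound 3 (beyond the scatter) among the steps shown. No measurement here accounts for why the step is this large.

Still open, on these data alone, is how other groups at this position would read, such as a longer chain carrying the hydroxycarbamoyl group, or a carboxylic acid in place of the hydroxycarbamoyl group. As far as these compounds go, the ethyl-linked group also appears only alongside the 4-methylphenyl group of compound 4, so the size of the step with 2-chlorophenyl or 4-cyanophenyl at the other end remains unknown.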